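The source may hold more compounds than are shown below. What is called first, only, known or untested is meant among the compounds shown, and "the series" means these compounds.

Three compounds built on a shared core have been examined in a functional assay on SK-MEL-2 cells (Homo sapiens) for antiproliferative activity; on this read-out lower numbers stand for an effect already at smaller amounts and higher numbers for an effect only at larger amounts of compound. Compound 1 `C(=C/c1cccs1)\c1cc(-c2cccs2)cc(-c2cccs2)n1` gives 118000 nM in this assay. Compound 2 `c1ccc(-c2cc(-c3cccs3)nc(-c3cccs3)c2)nc1` gives 118000 nM in this assay, and compound 3 `C(=C/c1ccco1)\c1cc(-c2ccco2)cc(-c2cccs2)n1` gives 118000 nM in this assay. On these numbers compound 2 stands level with compounds 1 and 3 at the digits shown: compound 1 is its nearest neighbour with no change at the digits shown, and compound 3 is its furthest with likewise no change at the digits shown, both within the scatter.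

Compound 4 `c1csc(-c2cc(-c3cccs3)nc(-c3cccs3)c2)c1` differs from compound 2 in one place: thiophen-2-yl in place of pyridin-2-yl on an aromatic carbon. Going by the values given here, no pair of measured compounds shows this change, so no step for it is known. Given that all three measured compounds, with compound 3 among them, sit at 118000 nM without any separation, the change to compound 4 is expected to bring no step beyond the scatter in this assay, in neither direction. Compound 4 is therefore estimated to give 118000 nM in this assay, with a range from 50000 nM to 250000 nM. The step this estimate means is no change at the digits printed from compound 2 to compound 4 (within the scatter), which is expected to stay within the scatter.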

Compound 4, half-maximal effective concentration: 118000 nM
Compound 4: the middle estimate sits on the measured number at the digits printed, within the range that was stated.
By their numbers in this assay, from the lowest: compounds 1, 2, 3 and 4 (each within the scatter of the next).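

In this assay the aromatic carbon opposite the ring nitrogen now has its first direct reading: thiophen-2-yl in place of pyridin-2-yl gives no change at the digits printed from compound 2 to compound 4 (within the scatter) and so leaves the two compounds level, even though a five-membered aromatic ring enters where a six-membered one leaves. A second exchange can now be read as well, with thiophen-2-yl in place of 2-(thiophen-2-yl)ethenyl on an aromatic carbon giving no change at the digits printed from compound 1 to compound 4 (within the scatter) and showing that this group too can be exchanged without any separation on this read-out. Nothing measured here offers an explanation for these level values.

With all four compounds printing the same number, the compounds shown do not reveal whether any group at the carbon opposite the ring nitrogen can separate from thiophen-2-yl and pyridin-2-yl on this read-out. On these data alone, what an amine, a carboxylic acid or a longer chain would give at that place remains open, as does whether such a group would stand level with compound 4 or apart from it.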